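This account rests on a few compounds, and the source may have more. Where it says the series, first, only, none or still open, it means among the compounds named here.

Measured compounds:
compound 1, `Cn1c(CN2CCN(c3ccc(Cl)cc3F)CC2)nc2ccccc21` — 2510 nM
compound 2, `Cn1c(CN2CCN(c3ccccc3F)CC2)nc2ccccc21` — 6310 nM

In a functional assay on CHO cells for agonist activity at metabotropic glutamate receptor 2 (Homo sapiens), read by FLIPR (a higher number here means that more compound is needed for the effect, a lower number that less compound is needed), compound 2 gives 6310 nM, the highest of the two numbers recorded. Its nearest neighbour is compound 1, which gives 2510 nM. For the measured compounds named here, the only measured step, a 2.5-fold higher number from compound 1 to compound 2 (0.40 log units; beyond the scatter), concerns the loss of chloro from the aromatic ring and is modest in size.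

Compound 3, `Cn1c(CN2CCN(c3ccccc3C(F)(F)F)CC2)nc2ccccc21`, differs from compound 2 in one place: trifluoromethyl in place of fluoro on an aromatic carbon. Going by the values given here, no measured step touches this exchange directly. Among the compounds with values here, the one step in hand, a 2.5-fold higher number from compound 1 to compound 2 (0.40 log units; beyond the scatter), shows that removing a group from that ring raised the number modestly, which offers only a weak hint that enlarging the group from fluoro to trifluoromethyl might lower it. Because the hint rests on a single step with a different group, a 2.5-fold higher number from compound 1 to compound 2 (0.40 log units; beyond the scatter), the expectation is a small step down that may not clear the scatter, with wide uncertainty.

Compound 3 is therefore expected to give about 4000 nM in this assay, with a likely range from 1000 nM to 16000 nM. This estimate corresponds to an expected step of a 1.6-fold lower number from compound 2 to compound 3 (0.20 log units; within the scatter).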

Compound 3, half-maximal effective concentration: > 15800 nM
Compound 3 ended at the assay's limit; the forecaster's own chance of this, stated with the estimate: 10%; at least 3.9-fold (0.59 log units) between middle value and limit.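

In this assay, the exchange of fluoro for trifluoromethyl, on an aromatic carbon ortho to a large group, gives an at least 2.5-fold higher number from compound 2 to compound 3 (0.39 log units; beyond the scatter), so the larger group at this position goes with more compound being needed rather than less. Compound 3 gives > 15800 nM, which is a limit of the assay and not a number, so the step has a lower bound on its size but no end point: the limit of > 15800 nM in this assay, at which 1 of the 3 values shown sits. The earlier step, a 2.5-fold higher number from compound 1 to compound 2 (0.40 log units; beyond the scatter), concerned chloro at a different place on the same ring and tied the presence of that group to a lower number, whereas the new step shows that adding heavy atoms to this ring does not lower the number at every place.

The true value of compound 3 remains unknown, and the three compounds shown cannot tell whether the number follows the size of the group at this position or some other feature of trifluoromethyl. Going by these compounds, it remains open how a methyl, a methoxy group or a nitrile would behave at this position, and whether chloro on the ring of compound 3 would lower its number as it does for compound 2.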